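Working notes on an E to Z configuration step

A few compounds are considered here, and "the series" means these few. Any claim that something is new, unique, unknown or untested is made for them only; others in the source may bear on it.

Measured compounds:
Compound 1 `COc1cc(/C=C/c2ccc(OC)c(O[C@@H]3O[C@H](C(=O)O)[C@@H](O)[C@H](O)[C@H]3O)c2O)cc(OC)c1OC`: in a functional assay on SK-OV-3 cells (Homo sapiens) for cytotoxicity, read by sulforhodamine B assay (a higher number here means a weaker inhibitor of growth, a lower number a stronger inhibitor of growth), compound 1 gives > 85000 nM, a limit of the assay rather than a number.
Compound 2 `COc1ccc(/C=C/c2cc(OC)c(OC)c(OC)c2)c(O[C@@H]2O[C@H](C(=O)O)[C@@H](O)[C@H](O)[C@H]2O)c1O`: in this assay compound 2 gives 30000 nM.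
Compound 3 `COc1ccc(/C=C\c2cc(OC)c(OC)c(OC)c2)c(O[C@@H]2O[C@H](C(=O)O)[C@@H](O)[C@H](O)[C@H]2O)c1O`: in this assay compound 3 gives 2300 nM.

Compound 1 stands only as a limit, as shown by the limit of > 85000 nM in this assay, at which 1 of the 3 values shown sits; no number is known for it, and compound 2 and compound 3 are the only compounds with numbers. The unmeasured compound 4 `COc1cc(/C=C\c2ccc(OC)c(O[C@@H]3O[C@H](C(=O)O)[C@@H](O)[C@H](O)[C@H]3O)c2O)cc(OC)c1OC` differs from compound 1 as follows: the two compounds have the same atoms and bonds and differ only in configuration as drawn: 1 of 6 stereo elements differ; a double bond is drawn E in compound 1 and Z in compound 4. Among the compounds with values here, one measured step bears on this change: a 13-fold lower number from compound 2 to compound 3 (1.12 log units; beyond the scatter), which rests on (the fact that compounds 2 and 3 differ only in the configuration as drawn). That step is large and runs toward a lower number. The same kind of change is therefore expected to lower the number from compound 1 to compound 4 as well, but since compound 1 is known only as a limit, the starting point is uncertain and the expected value is broad. The step expected is an at least 4.2-fold lower number from compound 1 to compound 4 (0.62 log units; beyond the scatter). Compound 4 is estimated at 20000 nM, with a range from 4000 nM to 90000 nM.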

Compound 4, concentration for 50% growth inhibition: 2100 nM
Compound 4: the middle estimate sits 9.5-fold (0.98 log units) above what was measured; measured number outside the range, below it.
By their numbers in this assay, from the lowest: compounds 4 and 3 (each within the scatter of the next); then compound 2. At a limit, above all of these: compound 1.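

In this assay the E to Z change now appears in a second pair, as an at least 40-fold lower number from compound 1 to compound 4 (1.60 log units; beyond the scatter), and the configuration is the only thing that differs within that pair: the fact that compounds 1 and 4 differ only in the configuration as drawn. Compound 1 gives > 85000 nM, which is a limit of the assay and not a number, so this step gives only a minimum size. The earlier compounds showed the direction in one pair, as a 13-fold lower number from compound 2 to compound 3 (1.12 log units; beyond the scatter), whereas it now holds in both pairs shown, with neither going against it.

The compounds shown leave open whether the E to Z step keeps its direction with a methyl ester in place of the carboxylic acid. Going by these compounds, it also remains open how large the step from compound 1 truly is.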